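Compound 3: methylsulfanyl ortho to the nitro group

The source may hold more compounds than are shown below. What is called first, only, known or untested is meant among the compounds shown, and "the series" means these compounds.

Two compounds in the series have numbers in an assay on Myocardium (Cavia porcellus) for displacement of a labelled ligand from Voltage-dependent L-type calcium channel subunit alpha-1C (Homo sapiens); a lower number here means tighter binding, a higher number weaker binding. Compound 1 `COC(=O)C1=C(C)N=C(SC)NC1c1ccccc1SC` gives 1520 nM in this assay. Compound 2 `CSC1=NC(c2cccc([N+](=O)[O-])c2)C2=C(O)OCC2=N1` gives 36900 nM in this assay, the higher of the two numbers, and its distance from compound 1 lies beyond the scatter; the two compounds differ in more than one place, so the pair says nothing about any single change.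

Compound 3 `CSC1=NC(c2cccc([N+](=O)[O-])c2SC)C2=C(O)OCC2=N1` has not yet been measured. It differs from compound 2 in one place: methylsulfanyl in place of hydrogen on an aromatic carbon. The new group sits on an aromatic carbon of a six-membered aromatic ring of carbon only, ortho to a large group and ortho to a nitro group.

Among the measured compounds shown here, no measured pair isolates this change. Compound 1 also carries a methylsulfanyl on its aromatic ring and gives 1520 nM in this assay, but its core differs, so it offers only a loose hint. The expected step from compound 2 to compound 3 is a 2.5-fold lower number from compound 2 to compound 3 (0.39 log units; beyond the scatter), a modest gain in binding that may not exceed the scatter. Compound 3 is expected to give about 15000 nM in this assay, within a range of 4000 nM to 60000 nM.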

Compound 3, dissociation constant: 13700 nM
The estimate for compound 3 lay 1.1-fold (0.04 log units) above the measured number, and the stated range covers the measured number.
By their numbers in this assay, from the lowest: compound 1; then compound 3; then compound 2.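

In this assay, among the compounds shown here, methylsulfanyl in place of hydrogen on an aromatic carbon gives a 2.7-fold lower number from compound 2 to compound 3 (0.43 log units; beyond the scatter) and provides the first single-place step. The step is modest, but it shows that this position, ortho to a large group and ortho to a nitro group, accepts the added methylsulfanyl without a loss of binding, with compound 3 at 13700 nM in this assay on the shared core. The data on hand offer no explanation for the size or direction of this step.

The compounds shown do not tell whether the gain is particular to methylsulfanyl or would also appear at this carbon with a methoxy group, a chlorine atom or an amine. Also open is whether the nitro group matters to the step, and whether the same change would give a similar step on the core of compound 1, which stands at 1520 nM in this assay and has no single-place partner among the compounds shown.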